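The source may hold more compounds than are shown below. What is called first, only, known or untested is meant among the compounds shown, and "the series" means these compounds.

In a functional assay on NCI-H460 cells (Homo sapiens) for cytotoxicity, read by sulforhodamine B assay, with a stated time of 24 h (on this read-out lower numbers stand for stronger inhibition and higher numbers for weaker inhibition), compound 1 `CC(=O)SCCCCC[C@H](NC(=O)[C@H]1CCC(=O)N1)C(=O)Nc1ccccc1` gives 70 nM. That value lies within the scatter of compound 2 `CC(=O)SCCCCC[C@H](NC(=O)[C@@H]1CC(=O)N1)C(=O)Nc1ccccc1`, which gives 50 nM, and far from compound 3 `CC(C)C(=O)SCCCCC[C@H](NC(=O)[C@@H]1CCCC(=O)N1)C(=O)NC1CCCCC1`, which gives the much higher 3700 nM. Compound 1 therefore belongs with the low numbers among these three compounds.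

Compound 4 `CC(=O)SCCCCC[C@H](NC(=O)[C@H]1CCC(=O)N1)C(=O)Nc1cccc(C(F)(F)F)c1` keeps the core of compound 1 and has trifluoromethyl in place of hydrogen on an aromatic carbon, turning phenyl into 3-(trifluoromethyl)phenyl: trifluoromethyl in place of hydrogen on an aromatic carbon.

Only one measured step connects two of these compounds, a 1.4-fold lower number from compound 1 to compound 2 (0.15 log units; within the scatter), and it stays within the scatter. It replaces 5-oxopyrrolidin-2-yl with 4-oxoazetidin-2-yl and leaves the phenyl group untouched, so it bears on the new change only indirectly. Compound 3 differs from compound 1 in several places at once, so its value cannot be assigned to any single change. Among the compounds with values here, no measured pair tests a substituent on the phenyl group, which leaves the size of this step untested by the data.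

With so little to go on, no step beyond the scatter is expected in this assay, and no firm direction can be given. The estimated step is a 1.2-fold lower number from compound 1 to compound 4 (0.07 log units; within the scatter). For compound 4 the expected value is 60 nM, with an estimated range from 20 nM to 180 nM.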

Compound 4, half-maximal inhibitory concentration: 30 nM
Beside the measured number, compound 4's estimate is 2.0-fold (0.30 log units) above it; measured number inside the range.
By their numbers in this assay, from the lowest: compounds 4, 2 and 1 (each within the scatter of the next, the first and the last beyond it); then compound 3.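

In this assay, within the data shown here, the phenyl group of compound 1 proves open to substitution, and adding trifluoromethyl gives the only step here that tests this group (a 2.3-fold lower number from compound 1 to compound 4 (0.37 log units; beyond the scatter)), a modest one that lies beyond the scatter. The only earlier single-place step (a 1.4-fold lower number from compound 1 to compound 2 (0.15 log units; within the scatter)) stayed within the scatter, so this is the first single change among these compounds that clearly moves the number, and it moves it towards stronger inhibition. Nothing measured here accounts for this step, which therefore stands as an observation without an explanation.

On these data alone, it remains open whether a methoxy group, a chlorine atom or an amine on the same aromatic carbon would move the number as trifluoromethyl does, and whether trifluoromethyl on another carbon of the ring would do the same. Also open, as far as these compounds go, is whether the change would give a similar step on compound 2, which carries 4-oxoazetidin-2-yl in place of 5-oxopyrrolidin-2-yl, since a single pair cannot show whether the step holds beyond the core of compound 1.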